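From compound 3 to compound 4 at the limit

A few compounds are considered here, and "the series" means these few. Any claim that something is new, unique, unknown or untested is made for them only; others in the source may bear on it.

Measured in an ADME assay on L02 cells (Homo sapiens) for cytotoxicity, read by MTT assay, with a stated time of 48 h; a lower number here means a stronger inhibitor, a higher number a weaker inhibitor:
- Compound 1 `O=C1O[C@@H](CN2CCC(O)CC2)CN1c1ccc(-n2cc(-c3ccccn3)cn2)c(F)c1`: > 400 ug/mL, a limit
- Compound 2 `O=C1CCC(=O)N1C[C@H]1CN(c2ccc(-n3cc(-c4ccccn4)cn3)c(F)c2)C(=O)O1`: > 400 ug/mL, a limit
- Compound 3 `O=C1CNC(=O)N1C[C@H]1CN(c2ccc(-n3cc(-c4ccccn4)cn3)c(F)c2)C(=O)O1`: > 400 ug/mL, a limit

Compound 3 has no number, only the limit > 400 ug/mL. The two other compounds also stand at a limit, so no order among the three can be read. Among the compounds with values here, the whole series so far comes down to the limit of > 400 ug/mL in this assay, at which 3 of the 3 values shown sit.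

The next compound is compound 4 `COC[C@H]1CN(c2ccc(-n3cc(-c4ccccn4)cn3)c(F)c2)C(=O)O1`, and the change that leads to it is methoxy in place of 2,5-dioxoimidazolidin-1-yl on a saturated chain carbon bound to a saturated ring carbon. Put simply, this is methoxy in place of 2,5-dioxoimidazolidin-1-yl on a saturated chain carbon bound to a saturated ring carbon.

The measured steps at this same place are a step that the two limits leave unreadable from compound 1 to compound 2, a step that the two limits leave unreadable from compound 1 to compound 3 and a step that the two limits leave unreadable from compound 2 to compound 3. None of them has a readable size, so they give neither a direction nor a magnitude for the new change. Within the data shown here, with the limit of > 400 ug/mL in this assay, at which 3 of the 3 values shown sit, as the only guide, no step beyond the scatter is expected in this assay, and another limit is the likeliest report. The expectation is weak, as the series holds no measured number yet.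

The expected step is a number no higher from compound 3 to compound 4 (the limit leaves the size open). The estimate for compound 4 is 400 ug/mL, with an expected range from 200 ug/mL to 800 ug/mL.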

Compound 4, half-maximal inhibitory concentration: > 400 ug/mL
Compound 4: only a limit was reported; the forecaster's own chance of this, stated with the estimate: 80%; the middle value sits exactly at the limit.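

In this assay compound 4 gives > 400 ug/mL, a limit, so its steps from compound 1, compound 2 and compound 3 cannot be read. The series stays where it stood: the limit of > 400 ug/mL in this assay, at which 4 of the 4 values shown sit.

The compounds shown leave open whether any of these four differ at all in this assay, and in which direction.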